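Series notes: step from compound 2 to compound 3

A few compounds are considered here, and "the series" means these few. Any claim that something is new, unique, unknown or untested is made for them only; others in the source may bear on it.

Of the compounds shown here, two have been tested in a functional assay on the whole organism (artery, strain albino) with Rattus norvegicus as the target, with a stated time of 15 min, at a dose of 10 mg/kg by the oral route; a higher number here means more inhibition at the dose given (going by the name of the read-out), a lower number less inhibition. Compound 1 `COc1ccc(C2N=C(SCc3ccc(F)cc3)NC(C)=C2C(=O)Nc2ccc(F)cc2)cc1OC` gives 3.6% there, and compound 2 `CC1=C(C(=O)Nc2ccc(Br)cc2)C(c2ccc(Cl)cc2Cl)N=C(SCc2ccccc2)N1` gives 1.5%. Compound 2 stands lowest of the two numbers, but the gap to compound 1 lies within the scatter, so the two read alike. For the measured compounds named here, no step between measured compounds differing in one place is available. Compound 3 `CC1=C(C(=O)Nc2ccc(Br)cc2)C(c2ccc(Cl)cc2Cl)N=C(SCc2ccc(Cl)cc2)N1` differs from compound 2 by chloro in place of hydrogen on an aromatic carbon. With both measured values near zero, the step of a number 1.5 percentage points higher from compound 2 to compound 3 (within the scatter) is expected to stay within the scatter, in no particular direction. Compound 3 is estimated at 3%, with a range from -6% to 12%.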

Compound 3, a percentage reported as inhibition, in the whole organism at one dose (the size of the read-out at that dose, not a potency): 4.1%
The estimate for compound 3 lay 1.1 percentage points below the measured number; low and high end bracket the measured number.
By their numbers in this assay, from the lowest: compounds 2, 1 and 3 (each within the scatter of the next).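

In this assay, the change from benzylsulfanyl to (4-chlorobenzyl)sulfanyl gives a number 2.6 percentage points higher from compound 2 to compound 3 (within the scatter) and so adds a read step at this position on a shared core. Chloro in place of hydrogen on this aromatic carbon leaves the read-out where compound 2 stood, and no separation from that number appears. No supporting measurement bears on this result.

Going by these compounds, what a carboxylic acid or an amine at this aromatic carbon would give remains open. Also open, on these data alone, is whether any replacement of the benzyl group, such as a longer alkyl chain, would move the read-out beyond the scatter.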